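Cell Toxicity Across Four Closely Related Compounds

The source may hold more compounds than are shown below. What is called first, only, known or untested is meant among the compounds shown, and "the series" means these compounds.

Compound 1, `CC(=O)Nc1ccc(-c2nc3cc(C(F)(F)F)ccc3n2C)cc1`: 46000 nM
Compound 2, `CC(=O)Nc1ccc(-c2nc3cc([N+](=O)[O-])ccc3[nH]2)cc1`: > 100000 nM (a limit)
Compound 3, `O=C(CN1CCCC1)Nc1ccc(-c2nc3ccccc3[nH]2)cc1`: 70000 nM

The three measured compounds were tested in an ADME assay on MDBK cells (Bos taurus) for cytotoxicity, read by MTT assay, with a stated time of 96 h; on this read-out lower numbers stand for higher toxicity in this test and higher numbers for lower toxicity in this test. In this assay compound 3 gives 70000 nM, the higher of the two numbers; compound 1, with 46000 nM, lies within the usual scatter of it, so no order between them can be read. For compound 2 this assay reports only a limit, > 100000 nM.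

Compound 4, `CC(=O)Nc1ccc(-c2nc3ccccc3[nH]2)cc1`, is not yet measured. It differs from compound 3 by hydrogen in place of pyrrolidin-1-yl on a saturated chain carbon bound to a carbonyl carbon, so that the ((pyrrolidin-1-yl)methyl)carbonyl becomes acetyl. Among the compounds with values here, no measured pair isolates this change, so the step from compound 3 to compound 4 is expected to be a 1.2-fold lower number from compound 3 to compound 4 (0.07 log units; within the scatter), not beyond the scatter. Compound 4 is therefore estimated at 60000 nM, between 25000 nM and 100000 nM.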

Compound 4, half-maximal cytotoxic concentration: > 100000 nM
Compound 4 gave a limit, no number (the forecaster's own chance of this, stated with the estimate: 25%); middle value at least 1.6-fold (0.22 log units) away from the limit.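

Within the data shown here, this is the first measured pair to isolate this change: putting hydrogen in place of pyrrolidin-1-yl on a saturated chain carbon bound to a carbonyl carbon gives, in this assay, an at least 1.4-fold higher number from compound 3 to compound 4 (0.15 log units; that floor lies within the scatter). That floor therefore shows no real change in toxicity, yet the true gap could be larger. The step between compound 2 and compound 4 cannot be read: the limit of > 100000 nM in this assay, at which 2 of the 4 values shown sit.

Still open, from the compounds shown here alone, is how far compound 4 actually differs from compound 3. Also open, going by these compounds, is what a primary amine, a carboxylic acid or a longer chain on this carbon would give in this assay.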